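Removing One Methoxy Group: A Small Step in Cell Viability

The source may report more compounds than this note shows. Statements on the series, on what has been measured and on what is new or still open speak of the compounds shown alone.

Of the compounds shown here, three have so far been measured in an ADME assay on HT-22 cells (Mus musculus) for cytotoxicity, read by MTT assay, with a stated time of 24 h, tested at 10 uM; on this read-out lower numbers stand for a stronger effect and higher numbers for a weaker effect at the one concentration tested. Compound 1 `COc1cc(CCCCC(=O)/C=C/c2ccc(O)cc2)ccc1O` gives 67%, compound 2 `COc1cc(/C=C/C(=O)CCCCc2ccc(O)c(OC)c2)ccc1O` gives 66%, and compound 3 `COc1cc(CCCCC(O)CCc2ccc(O)c(OC)c2)ccc1O` gives 73%. All three numbers lie within the usual scatter of one another, so none of them can be set apart from the rest on this read-out.

Compound 1 and compound 2 differ in one place only: hydrogen in place of methoxy on an aromatic carbon. That change made a number 1 percentage points higher from compound 2 to compound 1 (within the scatter). Compound 3 differs from compound 2 in more than one place, and the difference between the two cores is not broken down here.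

Compound 4 `COc1cc(CCCCC(O)CCc2ccc(O)cc2)ccc1O` has not yet been measured. It stands to compound 3 as compound 1 stands to compound 2: hydrogen in place of methoxy on an aromatic carbon. The place of the change reads the same word for word in both pairs, so it is the same change, made a second time on a different core. Because the same change earlier gave a number 1 percentage points higher from compound 2 to compound 1 (within the scatter), the step for compound 4 is expected to be a number 1 percentage points higher from compound 3 to compound 4 (within the scatter), an expectation that rests on that single earlier pair and on nothing more. The estimate for compound 4 in this assay is therefore 74%, expected to fall between 62% and 86%.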

Compound 4, a percentage reported as activity, at one concentration (the size of the read-out at that concentration, not a potency): 74%
Estimate against measurement, compound 4: no gap at the digits printed; the range from low to high includes it.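

In this assay, putting hydrogen in place of methoxy on an aromatic carbon gives a number 1 percentage points higher from compound 3 to compound 4 (within the scatter). Set beside the earlier pair, the same change reads alike on the two cores, with no difference that can be told apart: the same change on two cores in this assay, a number 1 percentage points higher (within the scatter) from compound 2 to compound 1 and a number 1 percentage points higher (within the scatter) from compound 3 to compound 4, 0 percentage points apart, within the scatter of two such steps This shows that the change can be carried from one of these cores to the other here without any visible departure, but both steps are within the scatter, so it does not show that removing the methoxy group has a real effect on this read-out in either direction, and a match between two small steps on only two cores, at a single concentration, says little about how the change would behave where a larger step appears.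

The compounds shown leave open what would happen if the methoxy group gave way to something other than hydrogen, such as an amine or a carboxylic acid, since hydrogen is the only replacement seen here. They also leave open whether the same small step would hold on a core with a longer chain, where the link between this change and the core could read differently.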